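Benzyloxy for methyl on the biaryl of compound 2

A few compounds are considered here, and "the series" means these few. Any claim that something is new, unique, unknown or untested is made for them only; others in the source may bear on it.

Among the measured compounds shown here, compound 2 `Cc1cccc(-c2ccc(NCc3ccccc3O)cc2)c1` is the higher of the two numbers measured so far. In a functional assay on Jurkat cells (Homo sapiens) for activation, with a stated time of 24 h (a higher number here means that more compound is needed for the effect, a lower number that less compound is needed), compound 2 gives 9190 nM. Its nearest neighbour, compound 1 `Oc1ccccc1CNc1ccc(-c2cccc(Cl)c2)cc1`, differs only by chloro in place of methyl on an aromatic carbon; in this assay compound 1 gives 6200 nM. For the measured compounds named here, the one measured step, a 1.5-fold higher number from compound 1 to compound 2 (0.17 log units; within the scatter), falls within the scatter, so the two compounds cannot be ordered.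

Compound 3 `Oc1ccccc1CNc1ccc(-c2cccc(OCc3ccccc3)c2)cc1` is the next change on the same carbon: benzyloxy in place of methyl on an aromatic carbon. Going by the values given here, no measured step exchanges a one-carbon substituent for a group of this size, so nothing here predicts the direction. Among the compounds with values here, the only step available, a 1.5-fold higher number from compound 1 to compound 2 (0.17 log units; within the scatter), shows that a small swap at this carbon stays within the scatter, which does not transfer to benzyloxy. For compound 3 in this assay a number near that of compound 2 is expected, with a wide range in both directions, giving an estimated 8000 nM between 2000 nM and 30000 nM. The step this estimate implies is a 1.1-fold lower number from compound 2 to compound 3 (0.06 log units; within the scatter), which is expected to stay within the scatter.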

Compound 3, half-maximal effective concentration: "not active" (no number reported)
Compound 3 has no reported number here, and the estimate cannot be compared.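

Among the compounds shown here, compound 3 is reported as "not active" in this assay, without a number, so no step from compound 2 to compound 3 can be read. The compounds shown leave open how benzyloxy on this aromatic carbon compares in number with methyl or chloro. Nothing available bears on this result.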